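Aryl carbamate series: bromo in place of ring hydrogen

The source may hold more compounds than are shown below. What is called first, only, known or untested is meant among the compounds shown, and "the series" means these compounds.

Within the data shown here, compound 1 `C=C1C(=O)OC[C@H]1CCOC(=O)Nc1ccccc1` gives 14800 nM in an ADME assay on RAW264.7 cells (Mus musculus) for cytotoxicity, read by MTT assay, with a stated time of 18 h (a higher number here means that more compound is tolerated, a lower number that less compound is tolerated), the second highest of the three numbers known. Compound 2 `C=C1C(=O)OC[C@H]1CCOC(=O)Nc1ccc(CCCC)cc1` gives 15900 nM and compound 3 `C=C1C(=O)OC[C@H]1CCOC(=O)Nc1ccc(CC)cc1` gives 11400 nM in this assay. The steps of a 1.1-fold higher number from compound 1 to compound 2 (0.03 log units; within the scatter) and a 1.3-fold lower number from compound 1 to compound 3 (0.11 log units; within the scatter) both fall within the scatter, as does a 1.4-fold lower number from compound 2 to compound 3 (0.14 log units; within the scatter). Compound 4 `C=C1C(=O)OC[C@H]1CCOC(=O)Nc1cccc(Br)c1` differs from compound 1 by bromo in place of hydrogen on an aromatic carbon. Among the measured compounds shown here, no measured step introduces bromo, so only the two alkyl steps from compound 1 bear on this change, and neither moved the number beyond the scatter. The step is therefore expected to be no change at the digits printed from compound 1 to compound 4 (within the scatter). Compound 4 is estimated at 14800 nM, with a range from 8000 nM to 27000 nM.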

Compound 4, half-maximal cytotoxic concentration: 21800 nM
Estimate against measurement, compound 4: 1.5-fold (0.17 log units) below, within the range that was stated.
By their numbers in this assay, from the lowest: compounds 3, 1, 2 and 4 (each within the scatter of the next).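

Bromo on an aromatic carbon, meta to a large group, is the first substituent at this place in the series, and the step in this assay, a 1.5-fold higher number from compound 1 to compound 4 (0.17 log units; within the scatter), shows that this place accepts a bromo without a change beyond the scatter. The two alkyl steps showed this only for their own groups at another place on the ring. No measurement available here bears on the reason for the size of this step.

On these data alone, whether an amine, a carboxylic acid or a longer chain at this same place would give a step beyond the scatter stays open. So does whether bromo at another place on the ring would behave alike.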